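This account rests on a few compounds, and the source may have more. Where it says the series, first, only, none or still open, it means among the compounds named here.

In a functional assay on DU-145 cells (Homo sapiens) for cytotoxicity, read by trypan blue exclusion, with a stated time of 96 h (on this read-out higher numbers stand for weaker inhibition and lower numbers for stronger inhibition), compound 1 `COc1cc(OC)c(/C=C/S(=O)(=O)Cc2ccc(OC)c(N)c2)c(OC)c1` gives 4 nM and compound 2 `COc1cc(OC)c(/C=C/S(=O)(=O)Cc2cc(N)ccc2OC)c(OC)c1` gives 7500 nM, so compound 2 holds the higher of the two numbers, meaning the weaker inhibition. Compound 3 `COc1cc(OC)c(/C=C/S(=O)(=O)Cc2ccc(Br)c(N)c2)c(OC)c1` follows from compound 2 with 3-amino-4-bromophenyl in place of 5-amino-2-methoxyphenyl on a saturated chain carbon bound to a sulfonyl sulfur. Within the data shown here, the one measured step bearing on this is a 1900-fold higher number from compound 1 to compound 2 (3.27 log units; beyond the scatter), which came with 5-amino-2-methoxyphenyl in place of 3-amino-4-methoxyphenyl. Among the measured compounds shown here, compound 3 carries 3-amino-4-bromophenyl, which has bromine where the group of compound 1 has methoxy, and no measured step covers that exchange. A large step to a lower number in this assay is therefore expected, though compound 3 is probably expected to keep a higher number than compound 1, which gives 4 nM. The expected change is a 94-fold lower number from compound 2 to compound 3 (1.97 log units; beyond the scatter). For compound 3 the estimated value is 80 nM, with an expected range of 8 nM to 1500 nM.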

Compound 3, half-maximal inhibitory concentration: 750 nM
Beside the measured number, compound 3's estimate is 9.4-fold (0.97 log units) below it; the measured number falls inside the stated range.
By their numbers in this assay, from the lowest: compound 1; then compound 3; then compound 2.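

With the amino group kept, a 190-fold higher number from compound 1 to compound 3 (2.27 log units; beyond the scatter) in this assay: a large step, and the only one shown that changes the methoxy group alone. Against that, a 10-fold lower number from compound 2 to compound 3 (1.00 log units; beyond the scatter) is only modest, so 3-amino-4-bromophenyl falls well short of 3-amino-4-methoxyphenyl and still improves on 5-amino-2-methoxyphenyl, which means that the methoxy group of compound 1 is not exchanged for bromine without a large rise in this pair. Nothing available accounts for the size of either step.

One exchange cannot separate a particular cost of bromine from a general demand for methoxy on that carbon; chlorine, methyl, ethoxy or hydroxyl there would bear on this. The role of the amino group also stays open, as no compound shown carries a hydroxyl or an acetamide in its place.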